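Clearance when an Amide Replaces the Methyl-Anilino Group

The compounds below may be only part of what the source reports. "The series", "measured", "known", "first", "only" and "open" are said of these compounds alone.

In an ADME assay on microsomes from liver (Homo sapiens) for metabolic stability, read by LC-MS, using NADPH, with stated times of 5 min and 30 min, tested at 1 uM (a higher number here means faster removal of the compound, a lower number slower removal), two compounds of this shared core have been measured. Compound 1 `O=C1c2ccccc2CN1c1cnc(NCc2c(F)ccc3c2CCO3)n2cnnc12` gives 13 mL.min-1.g-1 in this assay. Among the compounds with values here, compound 2 `CN(c1ccccc1)c1cnc(NCc2c(F)ccc3c2CCO3)n2cnnc12` gives 55 mL.min-1.g-1 in this assay, the highest of the two numbers, with compound 1 as its nearest neighbour; the single step of a 4.2-fold higher number from compound 1 to compound 2 (0.63 log units; beyond the scatter) lies beyond the scatter. Compound 3 `O=C(Nc1cnc(NCc2c(F)ccc3c2CCO3)n2cnnc12)c1ccccc1` is not yet measured in this assay. It differs from compound 2 in one place: benzamido in place of methyl(phenyl)amino on an aromatic carbon. Within the data shown here, the only measured step that bears on this change is a 4.2-fold higher number from compound 1 to compound 2 (0.63 log units; beyond the scatter), in which a group holding a carbonyl gave way to methyl(phenyl)amino; the move to compound 3 goes the other way, bringing a carbonyl back and exchanging methyl(phenyl)amino for benzamido. On that basis the number for compound 3 in this assay is expected to fall by a 3.1-fold lower number from compound 2 to compound 3 (0.49 log units; beyond the scatter), a step of the same order as that between compound 1 and compound 2 but in the opposite direction. Compound 3 is therefore estimated at 18 mL.min-1.g-1, within a range of 8 mL.min-1.g-1 to 45 mL.min-1.g-1.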

Compound 3, intrinsic clearance in microsomes: 10 mL.min-1.g-1
For compound 3 the middle estimate is 1.8-fold (0.26 log units) above the measured one; the range from low to high includes it.
By their numbers in this assay, from the lowest: compounds 3 and 1 (each within the scatter of the next); then compound 2.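

In this assay, the step of a 5.5-fold lower number from compound 2 to compound 3 (0.74 log units; beyond the scatter) shows that the low number of compound 1 does not depend on its five-membered non-aromatic ring, since the open-chain benzamido group, which also holds a carbonyl, gives a low number too. The step of a 1.3-fold lower number from compound 1 to compound 3 (0.11 log units; within the scatter) lies within the scatter, so the groups of compound 1 and compound 3 cannot be told apart here, and the amide hydrogen of benzamido makes no difference that can be read in this pair. Across these three compounds, on this aromatic carbon, the two groups holding a carbonyl stand together apart from methyl(phenyl)amino, and no compound shown goes against that, though no measurement here explains why the number moves with this change.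

Going by these compounds, whether the fall follows the carbonyl or the loss of the methyl on the nitrogen stays open; compound 2 and compound 3 differ in both, and a plain phenylamino group would separate the two. Also open, on these data alone, is how much the phenyl ring counts in either group, a question that an acetamido or a methylamino group on the same aromatic carbon would address.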